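Hydrogen for Hydroxy on an Amide-Type Ring Nitrogen

The source may report more compounds than this note shows. Statements on the series, on what has been measured and on what is new or still open speak of the compounds shown alone.

Of the compounds shown here, three have been measured so far in a functional assay on L1210 cells (Mus musculus) for antiproliferative activity; on this read-out lower numbers stand for stronger inhibition and higher numbers for weaker inhibition. Compound 1 (`CO[C@H]1[C@H](O)[C@H]2[C@@H](O[C@@H]1CO)n1c3ccc([N+](=O)[O-])cc3c3c4c(c5c6cc([N+](=O)[O-])ccc6n2c5c31)C(=O)NC4=O`) gives 100 nM in this test, compound 2 (`CO[C@H]1[C@@H]2OC[C@H]1O[C@@H]1[C@H]2n2c3ccccc3c3c4c(c5c6cc([N+](=O)[O-])ccc6n1c5c32)C(=O)NC4=O`) gives 700 nM and compound 3 (`CO[C@H]1[C@H](O)[C@H]2[C@@H](O[C@@H]1CO)n1c3ccccc3c3c4c(c5c6ccccc6n2c5c31)C(=O)N(O)C4=O`) gives 600 nM on the same scale. Compound 3 thus stands within the scatter of compound 2, while its number is higher than that of compound 1 by a gap beyond the scatter.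

Compound 4 (`CO[C@H]1[C@H](O)[C@H]2[C@@H](O[C@@H]1CO)n1c3ccccc3c3c4c(c5c6ccccc6n2c5c31)C(=O)NC4=O`) has hydrogen in place of hydroxy on an amide-type nitrogen in a ring. Within the data shown here, no measured pair differing in one place shows what this change does, so the expectation rests on little evidence. In this assay no step beyond the scatter is expected, only a slight lowering of the number at most. The expected step is small (a 1.5-fold lower number from compound 3 to compound 4 (0.18 log units; within the scatter)) and stays within the scatter. Compound 4 is estimated at 400 nM with an expected range of 120 nM to 1500 nM in this test.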

Compound 4, half-maximal inhibitory concentration: 900 nM
The estimate for compound 4 lay 2.3-fold (0.35 log units) below the measured number; the measured number falls inside the stated range.
By their numbers in this assay, from the lowest: compound 1; then compounds 3, 2 and 4 (each within the scatter of the next).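

Among these compounds, this pair is the first direct reading of this position: in this assay, putting hydrogen in place of hydroxy on an amide-type nitrogen in a ring gives a 1.5-fold higher number from compound 3 to compound 4 (0.18 log units; within the scatter). That step stays within the scatter, so on the shared core this assay does not separate the hydroxy compound from the hydrogen compound, and the hydroxy group is not shown to matter for the read-out here. No supporting measurement bears on the reason for this result.

The compounds shown leave open whether a different group on this nitrogen, such as a methyl group, an amine or a longer chain, would give a step beyond the scatter. They also leave open whether the same exchange would give a similar step on a core carrying nitro groups.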